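Swapping acetyl for benzyl on a brominated core

A few compounds are considered here, and "the series" means these few. Any claim that something is new, unique, unknown or untested is made for them only; others in the source may bear on it.

Values measured in a functional assay on U-937 cells (Homo sapiens) for cytotoxicity, read by MTT assay, with a stated time of 24 h (a lower number here means a stronger inhibitor, a higher number a weaker inhibitor), are these.

- Compound 1 `CC(=O)Oc1c(Br)cc(Br)cc1Oc1ccc(Br)cc1Br` gives 32.3 ug/mL
- Compound 2 `CC(C)(C)OC(=O)N1CCN(CCCCCOc2c(Br)cc(Br)cc2Oc2ccc(Br)cc2Br)CC1` gives 35.5 ug/mL
- Compound 3 `Cc1ccc(S(=O)(=O)n2nc(N3CCN(CCCCCOc4c(Br)cc(Br)cc4Oc4ccc(Br)cc4Br)CC3)c3cc([N+](=O)[O-])ccc32)cc1` gives 68.5 ug/mL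

Compound 1 sits at the strong end of this small set, level with compound 2, since their two values lie within the usual scatter of each other. Compound 3 has a higher number, which means a weaker effect, and its gap to compound 1 lies beyond the scatter.

Compound 4 `Brc1ccc(Oc2cc(Br)cc(Br)c2OCc2ccccc2)c(Br)c1` has not yet been measured. Its structure differs from compound 1 in one place: benzyl in place of acetyl on an oxygen on an aromatic ring. In short, the acetoxy of compound 1 becomes benzyloxy.

Among the compounds with values here, no measured pair shows this change alone, so the expectation rests on loose evidence. The same oxygen carries a much larger group in compound 2, which still gives 35.5 ug/mL, and in compound 3, which gives 68.5 ug/mL. Those two values suggest a small rise in the number or no change beyond the scatter. The estimated change is a 1.2-fold higher number from compound 1 to compound 4 (0.09 log units; within the scatter). For compound 4 the expected value is 40 ug/mL, with an estimated range from 20 ug/mL to 80 ug/mL.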

Compound 4, half-maximal inhibitory concentration: 29 ug/mL
Compound 4: the middle estimate sits 1.4-fold (0.14 log units) above what was measured, and the stated range covers the measured number.
By their numbers in this assay, from the lowest: compounds 4, 1, 2 and 3 (each within the scatter of the next, the first and the last beyond it).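

Within this assay, the change from acetoxy to benzyloxy gives a 1.1-fold lower number from compound 1 to compound 4 (0.05 log units; within the scatter), and this is the first pair shown that differs in one place only. The step stays within the scatter, so at this oxygen on an aromatic ring, acetyl can give way to benzyl without a measurable shift in this read-out, even though benzyl brings a six-membered aromatic ring and takes away the double bond and hydrogen-bond acceptor of acetyl. Nothing shown here explains why the read-out holds steady across this swap.

A single pair cannot tell whether other groups on the same oxygen would behave in the same way, such as a small methyl, a longer alkyl chain without the piperazine-type ring system, or a benzyl carrying a carboxylic acid or an amine. The bromines on the shared core also remain untested, as every compound shown carries them, so the effect of replacing them with chlorine or hydrogen is open.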